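This account rests on a few compounds, and the source may have more. Where it says the series, first, only, none or still open, it means among the compounds named here.

Compound 2 `CN(C)c1ccc(C(=O)N[C@@H](CCCCCC(=O)NO)C(=O)NCc2ccccn2)cc1` gives 33000 nM in a functional assay on NFF cells (Homo sapiens) for antiproliferative activity (on this read-out lower numbers stand for stronger inhibition and higher numbers for weaker inhibition), the highest of the two numbers in hand; compound 1 `O=C(CCCCC[C@H](NC(=O)c1ccc(Br)cc1)C(=O)NCc1ccccc1)NO` gives 5860 nM, a gap that lies beyond the scatter. Compound 3 `O=C(CCCCC[C@H](NC(=O)c1ccc(Br)cc1)C(=O)NCc1ccccn1)NO` follows from compound 2 by bromo in place of dimethylamino on an aromatic carbon, the bromo being the same group that compound 1 carries, though compound 1 also differs elsewhere. No step between measured compounds isolates this change, so a moderate drop in the number, beyond the scatter, is expected, shown as a 3.7-fold lower number from compound 2 to compound 3 (0.56 log units; beyond the scatter). For compound 3 the expected value is 9000 nM, within 3000 nM to 27000 nM.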

Compound 3, half-maximal inhibitory concentration: 2090 nM
Beside the measured number, compound 3's estimate is 4.3-fold (0.63 log units) above it; the whole stated range lies above it.
By their numbers in this assay, from the lowest: compound 3; then compound 1; then compound 2.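

In this assay, bromo in place of dimethylamino on an aromatic carbon para to a large group gives a 16-fold lower number from compound 2 to compound 3 (1.20 log units; beyond the scatter) as a large step, so this position clearly matters to the read-out. Pyridin-2-yl in place of phenyl gives a 2.8-fold lower number from compound 1 to compound 3 (0.45 log units; beyond the scatter) as a modest step, so the group on the saturated chain carbon bound to the amide-type nitrogen also matters. Nothing at hand explains either step.

From the compounds shown here alone, whether chloro or methoxy on the same aromatic carbon would match bromo remains open. So does whether the pyridin-2-yl step holds with dimethylamino on that carbon.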